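Trading Chloro for Trifluoromethyl on the Benzyl Arm

The source may hold more compounds than are shown below. What is called first, only, known or untested is meant among the compounds shown, and "the series" means these compounds.

Of the compounds shown here, two have been measured. Compound 1, `O=C(NCc1cn(Cc2ccc(C(F)(F)F)cc2)nn1)c1cn(-c2ccccc2)nc1-c1ccc(F)cc1`, gives 250 nM in a functional assay on HeLa cells (Homo sapiens) for antiproliferative activity, read by sulforhodamine B assay, with a stated time of 48 h; on this read-out lower numbers stand for stronger inhibition of growth and higher numbers for weaker inhibition of growth. Going by the values given here, compound 2, `COc1ccc(-c2nn(-c3ccccc3)cc2C(=O)NCc2cn(Cc3ccc(Cl)cc3)nn2)cc1`, gives 6400 nM in this assay, the higher of the two numbers; its only neighbour is compound 1, whose number is lower by a margin well beyond the scatter. Compound 1 and compound 2 differ in two places at once, so their two values alone do not show which change carries the gap.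

Compound 3, `COc1ccc(-c2nn(-c3ccccc3)cc2C(=O)NCc2cn(Cc3ccc(C(F)(F)F)cc3)nn2)cc1`, has not yet been measured. It differs from compound 2 in one place: trifluoromethyl in place of chloro on an aromatic carbon. In this way compound 3 carries the same benzyl group as compound 1 while leaving everything else in compound 2 unchanged. A moderate step toward a lower number is expected from compound 2 to compound 3, because compound 1 gives 250 nM with that same benzyl group, although its second difference from compound 2 leaves the share owed to the benzyl change unknown. The step expected from this change is a 2.6-fold lower number from compound 2 to compound 3 (0.41 log units; beyond the scatter). Compound 3 is estimated at 2500 nM in this assay, within a range of 600 nM to 10000 nM.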

Compound 3, concentration for 50% growth inhibition: 6200 nM
For compound 3 the middle estimate is 2.5-fold (0.39 log units) below the measured one; the measured number falls inside the stated range.
By their numbers in this assay, from the lowest: compound 1; then compounds 3 and 2 (each within the scatter of the next).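

In this assay, trifluoromethyl in place of chloro on an aromatic carbon para to a large group gives a 1.0-fold lower number from compound 2 to compound 3 (0.01 log units; within the scatter) and so makes no measurable difference here, even though trifluoromethyl brings more heavy atoms than chloro. With the 4-(trifluoromethyl)benzyl arm held the same, methoxy in place of fluoro on an aromatic carbon gives a 25-fold higher number from compound 1 to compound 3 (1.39 log units; beyond the scatter) and this large step shows that the earlier gap between the first two compounds goes with the methoxy-for-fluoro change and not with the benzyl change. No measurement shown here explains either the flat step or the large one.

As far as these compounds go, it remains open whether chloro and trifluoromethyl would also match in a compound carrying fluoro instead of methoxy, as the direct comparison of these two benzyl groups exists only with methoxy present, and a flat step in one setting need not hold in another. Also open, from the compounds shown here alone, is how other groups would read at these two places, such as a nitrile or an amine on the benzyl ring, or a hydroxyl or plain hydrogen where fluoro and methoxy sit.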